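A Symmetric Fluorinated Counterpart to Compound 3

A few compounds are considered here, and "the series" means these few. Any claim that something is new, unique, unknown or untested is made for them only; others in the source may bear on it.

Within the data shown here, compound 3 `O=C(Nc1nc2ccccc2nc1Nc1ccc(F)cc1)c1ccccc1` gives 12700 nM in a functional assay on LNCaP C4-2 cells (Homo sapiens) for cytotoxicity, with a stated time of 72 h (a higher number here means a weaker inhibitor, a lower number a stronger inhibitor), the lowest of the three numbers so far, although that position carries no weight, since compound 1 `CC(C)(C)c1ccc(Nc2nc3ccccc3nc2Nc2ccc(C(C)(C)C)cc2)cc1` with 18600 nM and compound 2 `Cc1cccc(Nc2nc3ccccc3nc2Nc2cccc(C)c2C)c1C` with 17600 nM both lie within the scatter of it. Compound 4 `Fc1ccc(Nc2nc3ccccc3nc2Nc2ccc(F)cc2)cc1` has not yet been measured. It differs from compound 3 in one place: 4-fluorophenyl in place of benzoyl on a nitrogen on an aromatic ring. Both nitrogens of compound 4 thus carry a 4-fluorophenyl, a symmetric arrangement shared in kind with compound 1 and compound 2. Among the measured compounds shown here, no measured step matches this change, so the expected step of a 1.2-fold higher number from compound 3 to compound 4 (0.07 log units; within the scatter) is judged small, within the scatter or slightly upward. Compound 4 is therefore expected to give about 15000 nM, in a range from 6000 nM to 40000 nM.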

Compound 4, half-maximal inhibitory concentration: 3100 nM
Beside the measured number, compound 4's estimate is 4.8-fold (0.68 log units) above it; the whole stated range lies above it.
By their numbers in this assay, from the lowest: compound 4; then compounds 3, 2 and 1 (each within the scatter of the next).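

In this assay, replacing benzoyl with 4-fluorophenyl on a nitrogen on an aromatic ring gives a 4.1-fold lower number from compound 3 to compound 4 (0.61 log units; beyond the scatter) and so moves the number beyond the scatter. Among these compounds, the earlier compounds offered no step at all, so this is the first sign that the group at this place can change the number. Nothing available bears on why the step occurs.

On these data alone, it remains open whether a plain phenyl, a 4-methoxyphenyl or a 4-aminophenyl at this place would give a similar number, and so whether the fluorine matters.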